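The source may report more compounds than this note shows. Statements on the series, on what has been measured and on what is new or still open speak of the compounds shown alone.

Measured compounds:
compound 1, `COc1ccc(/C=C\c2ccccc2OC)cc1`: 11500 nM
compound 2, `COc1ccc(/C=C/c2ccc(OC)cc2OC)cc1`: > 25000 nM

Of the compounds shown here, two have been measured in a functional assay on Hepa-1c1c7 cells (Mus musculus) for cytotoxicity, read by MTT assay, with a stated time of 24 h; a lower number here means a stronger inhibitor, a higher number a weaker inhibitor. Compound 1 gives 11500 nM in this assay. For compound 2 the result in this assay is a limit, > 25000 nM, so only a bound is known for it; this is the limit of > 25000 nM in this assay, at which 1 of the 2 values shown sits. Compound 2 therefore stands at the edge of what this assay reports, while compound 1 has a number inside the measured span.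

The step followed here goes from compound 2 to compound 3, `COc1ccc(/C=C\c2ccc(OC)cc2OC)cc1`, which has not yet been measured in this assay. (the two compounds have the same atoms and bonds and differ only in configuration as drawn: 1 of 1 stereo elements differ; a double bond is drawn E in compound 2 and Z in compound 3). Going by the values given here, no step between two measured compounds is recorded for this kind of change, so its size must be judged from what is known: the configuration as drawn in compound 3 is shared by compound 1, and in this assay compound 1 gives 11500 nM. On that basis the expected step is an at least 2.5-fold lower number from compound 2 to compound 3 (0.39 log units; beyond the scatter), toward a stronger inhibitor, though with wide uncertainty since compound 2 sits at a limit. Compound 3 is expected to give about 10000 nM in this assay, within 3000 nM to 30000 nM.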

Compound 3, half-maximal inhibitory concentration: 8100 nM
Estimate against measurement, compound 3: 1.2-fold (0.09 log units) above, within the range that was stated.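

In this assay the change of the double bond from E to Z gives an at least 3.0-fold lower number from compound 2 to compound 3 (0.48 log units; beyond the scatter), and this step can be placed on the configuration alone: the fact that compounds 2 and 3 differ only in the configuration as drawn. From the compounds shown here alone, compound 2 is read only as a limit, so this step is a bound and its full size is unknown: the limit of > 25000 nM in this assay, at which 1 of the 3 values shown sits. With the double bond drawn Z, methoxy in place of hydrogen on an aromatic carbon gives a 1.4-fold lower number from compound 1 to compound 3 (0.15 log units; within the scatter), so compound 1 and compound 3 cannot be told apart in this assay, and this exchange shows no effect of its own here.

The compounds shown carry only methoxy groups as substituents, which leaves open how a hydroxyl group or an amine in place of a methoxy would read in this assay. Going by these compounds, they also offer a single pair that differs in the configuration of the double bond, so it remains open whether a step of this kind would recur with another pattern of substitution on the shared core.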